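This account rests on a few compounds, and the source may have more. Where it says the series, first, only, none or still open, it means among the compounds named here.

Measured in a functional assay on HepG2 cells (Homo sapiens) for cytotoxicity, with a stated time of 24 h; a lower number here means a stronger inhibitor, a higher number a weaker inhibitor:

compound 1 `COc1cc(Cl)ccc1C(=O)Nc1cc(Cl)c(Cl)cc1O` gives 11500 nM
compound 2 `COc1ccc(Cl)cc1C(=O)Nc1ccc(C(F)(F)F)cc1O` gives 4910 nM
compound 3 `COc1ccc(Cl)cc1C(=S)Nc1ccc(Cl)cc1O` gives 4450 nM

Compound 3, at 4450 nM, lies within the scatter of compound 2, so these two numbers cannot be told apart. Compound 1 has the higher number, and its distance from compound 3 lies beyond the scatter.

The next compound to be tested is compound 4 `COc1ccc(Cl)cc1C(=S)Nc1cc(Cl)c(Cl)cc1O`. It comes from compound 3 by a single change: chloro in place of hydrogen on an aromatic carbon. In words, a chloro group takes the place of a hydrogen on an aromatic carbon, ortho to a chloro group and para to a hydroxy group.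

Among the measured compounds shown here, no pair of measured compounds differs in one place only, so the effect of this change has not been measured directly. Compound 1, at 11500 nM, carries the same added chloro group, but it also differs from compound 4 elsewhere, so it offers only a weak hint. Little movement is therefore expected, with no clear direction. The estimated step is a 1.1-fold lower number from compound 3 to compound 4 (0.05 log units; within the scatter) and stays within the scatter. In this assay the estimate for compound 4 is 4000 nM (expected range 1700 nM to 9500 nM).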

Compound 4, half-maximal inhibitory concentration: 3720 nM
For compound 4 the middle estimate is 1.1-fold (0.03 log units) above the measured one; low and high end bracket the measured number.
By their numbers in this assay, from the lowest: compounds 4, 3 and 2 (each within the scatter of the next); then compound 1.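

Among the compounds shown here, the pair of compound 3 and compound 4 gives the first direct reading of this change in this assay, and adding a chloro group to the aromatic carbon that is ortho to a chloro group and para to a hydroxy group gives a 1.2-fold lower number from compound 3 to compound 4 (0.08 log units; within the scatter), so the two numbers cannot be told apart. This position therefore takes a chloro group with no shift that this assay can resolve, which compound 1 could not show, as it carries the same chloro group but also differs from compound 4 elsewhere. No measurement shown here offers an explanation for this result.

As far as these compounds go, it remains open whether a different group at this same carbon, such as an amine, a carboxylic acid or a longer chain, would move the number beyond the scatter. From the compounds shown here alone, it is also open whether this chloro group would give a similar step on a compound with a carbonyl in place of the thiocarbonyl.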